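Compound 2 and a bromophenyl swap in HepG2 cells

The compounds below may be only part of what the source reports. "The series", "measured", "known", "first", "only" and "open" are said of these compounds alone.

Compound 1 `COc1ccc(/C=C2\CN(C)C/C(=C\c3ccccc3F)C2=O)cc1OC` gives 8760 nM
Compound 2 `CN1C/C(=C\c2cccc([N+](=O)[O-])c2)C(=O)/C(=C/c2ccccc2F)C1` gives 1080 nM
Compound 3 `COc1cc(/C=C2\CN(C)C/C(=C\c3ccc(Cl)c(Cl)c3)C2=O)cc(OC)c1OC` gives 6960 nM

These three numbers come from a functional assay on HepG2 cells (Homo sapiens) for cytotoxicity, read by MTT assay, with a stated time of 24 h (a lower number here means a stronger inhibitor, a higher number a weaker inhibitor), where a lower number marks a stronger effect on the cells. Compound 2 has the lowest number of the three, and its gaps to compound 3 and to compound 1 both lie beyond the usual scatter of repeated measurements.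

The next molecule is compound 4 `CN1C/C(=C\c2ccc(Br)cc2)C(=O)/C(=C/c2cccc([N+](=O)[O-])c2)C1`, which has not yet been measured. It differs from compound 2 in one place: 4-bromophenyl stands in place of 2-fluorophenyl on a double-bonded chain carbon bound to a double-bonded ring carbon (4-bromophenyl in place of 2-fluorophenyl on a double-bonded chain carbon bound to a double-bonded ring carbon).

Among the compounds with values here, no measured pair shows this swap directly, so any expectation is rough. Compound 1 (8760 nM) also carries 2-fluorophenyl, yet its number is far from that of compound 2, so that group alone does not settle the value. Compound 4 keeps the rest of compound 2, which suggests a number near it. The expected change in this assay is a small rise, a 1.7-fold higher number from compound 2 to compound 4 (0.22 log units; within the scatter), which would stay within the scatter. For compound 4 the estimate is 1800 nM, with an expected range from 600 nM to 5500 nM.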

Compound 4, half-maximal inhibitory concentration: 8800 nM
Compound 4: the middle estimate sits 4.9-fold (0.69 log units) below what was measured, outside the stated range (above it).
By their numbers in this assay, from the lowest: compound 2; then compounds 3, 1 and 4 (each within the scatter of the next).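

In this assay, putting 4-bromophenyl in place of 2-fluorophenyl on a double-bonded chain carbon bound to a double-bonded ring carbon gives an 8.1-fold higher number from compound 2 to compound 4 (0.91 log units; beyond the scatter) and is the first change shown here that can be read on its own. This position is therefore sensitive to which substituted phenyl group it carries, at least with the rest of compound 2 held fixed. The two groups match in heavy atoms counted, in having one six-membered aromatic ring of carbon only, in hydrogen-bond donors and acceptors, and in net charge, so those counts do not account for the step, and no measurement at hand gives a reason for it.

The swap changes both the halogen, from fluorine to bromine, and its place on the phenyl ring, and the compounds shown cannot separate these two changes. Also open, on these data alone, is whether 4-fluorophenyl, 2-bromophenyl or a phenyl ring carrying an amine would stay close to compound 2 or close to compound 4 in this series.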